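The compounds below may be only part of what the source reports. "The series", "measured", "known", "first", "only" and "open" are said of these compounds alone.

The series is followed in a functional assay on HT-29 cells (Homo sapiens) for inhibition, read by MTT assay, with a stated time of 72 h; a lower number here means a stronger inhibitor, a higher number a weaker inhibitor. Within the data shown here, compound 1 `COc1cc(Oc2cccc(Nc3ccccc3)c2)cc(OC)c1CNCc1ccccc1` gives 3340 nM in this assay, the lower of the two numbers measured so far. Compound 2 `COc1ccc(CCCNCc2c(OC)cc(Oc3ccc(Nc4ccccc4)cc3)cc2OC)cc1` gives 6890 nM in this assay, a higher number than compound 1, with a gap that lies beyond the usual scatter. The step under consideration leads from compound 1 to compound 3 `COc1cc(Oc2cccc(Nc3ccccc3)c2)cc(OC)c1CNCc1ccc(C)cc1`, which has not yet been measured. The change is methyl in place of hydrogen on an aromatic carbon. Among the measured compounds shown here, no measured pair in the set shows this change, so no step of that kind has been recorded. With compound 1 at 3340 nM as the starting point, the step of a 1.0-fold lower number from compound 1 to compound 3 (0.02 log units; within the scatter) is expected to be modest, and no direction beyond the scatter is expected. Compound 3 is therefore estimated at 3200 nM, with a range from 1500 nM to 7000 nM.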

Compound 3, half-maximal inhibitory concentration: 3880 nM
Beside the measured number, compound 3's estimate is 1.2-fold (0.08 log units) below it; measured number inside the range.
By their numbers in this assay, from the lowest: compounds 1, 3 and 2 (each within the scatter of the next, the first and the last beyond it).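

Methyl in place of hydrogen on an aromatic carbon, para to a large group, turning benzyl into 4-methylbenzyl, gives a 1.2-fold higher number from compound 1 to compound 3 (0.07 log units; within the scatter) in this assay, so at this position a methyl cannot be told apart from hydrogen. Among these compounds, this is the only step on record, as compound 1 and compound 2 differ in more than one place and offered no such reading. No measurement in hand speaks to why the two numbers stand so close. The compounds shown leave open whether a trifluoromethyl group, an amine or a carboxylic acid on this same carbon would also stay within the scatter of compound 1. They also leave open whether a methyl on another carbon of this ring would read the same way.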